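The source may report more compounds than this note shows. Statements on the series, on what has been measured and on what is new or still open speak of the compounds shown alone.

Compound 1 (`Cc1ccc(S(=O)(=O)OCCCc2cn(-c3cccc(C#N)c3)nn2)cc1`) and compound 2 (`Cc1ccc(S(=O)(=O)OCCCc2cn(-c3cccc(F)c3)nn2)cc1`) share one core and differ in a single group. In a functional assay on HepG2 cells (Homo sapiens) for cytotoxicity, read by MTT assay, with a stated time of 72 h (a higher number here means a weaker inhibitor, a lower number a stronger inhibitor), compound 1 gives 44900 nM and compound 2 gives 82100 nM. These two numbers lie within the usual scatter of each other, so compound 2 stands level with compound 1, and neither can be called the stronger.

Compound 3 (`Cc1ccc(-n2cc(CCCOS(=O)(=O)c3ccc(C)cc3)nn2)cc1`) keeps the core and exchanges one group: 4-methylphenyl in place of 3-fluorophenyl on an aromatic nitrogen. In words, 4-methylphenyl takes the place of 3-fluorophenyl on an aromatic nitrogen.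

Among the compounds with values here, only one measured step bears on this change. That step, a 1.8-fold higher number from compound 1 to compound 2 (0.26 log units; within the scatter), came from fluoro in place of cyano on an aromatic carbon, and on its size no step beyond the scatter is expected in this assay for the new exchange, in either direction. Within the data shown here, a single step is thin evidence, and no measured compound carries 4-methylphenyl, so the range is kept wide.

The estimate amounts to an expected 1.3-fold lower number from compound 2 to compound 3 (0.10 log units; within the scatter). For compound 3 the estimated value is 65000 nM, with an expected range from 28000 nM to 150000 nM.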

Compound 3, half-maximal inhibitory concentration: 100000 nM
For compound 3 the middle estimate is 1.5-fold (0.19 log units) below the measured one; measured number inside the range.
By their numbers in this assay, from the lowest: compounds 1, 2 and 3 (each within the scatter of the next, the first and the last beyond it).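

In this assay, within the data shown here, moving from 3-fluorophenyl to 4-methylphenyl on the aromatic nitrogen gives no step that can be told apart from the scatter (a 1.2-fold higher number from compound 2 to compound 3 (0.09 log units; within the scatter)), so compound 2 and compound 3 stand level. Set against the nitrile-bearing group, however, 4-methylphenyl gives the first step in this small set that lies beyond the scatter (a 2.2-fold higher number from compound 1 to compound 3 (0.35 log units; beyond the scatter)), though it is only modest and rests on a single pair, while compound 2 remains level with both neighbours. This position therefore accepts a carbon-only substituent in place of fluoro without a readable step, and the only separation seen is between the two ends of the series, compound 1 and compound 3; nothing available gives a reason for that separation.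

All three compounds shown keep a substituted phenyl ring on the aromatic nitrogen, so it remains open how an amine or a carboxylic acid on that ring, or a plain alkyl chain in its place, would read in this assay. On these data alone, the shared sulfonate ester and its chain also stay unchanged here, so what a longer chain would do is equally open.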